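A few compounds are considered here, and "the series" means these few. Any claim that something is new, unique, unknown or untested is made for them only; others in the source may bear on it.

Compound 1 `O=C(c1ccc(-c2nc(-c3ccccn3)no2)s1)C(F)(F)F` carries a trifluoromethyl ketone on a thiophene that is joined to a five-membered ring bearing a pyridin-2-yl group. In an assay on isolated protein for inhibition of protein deacetylase HDAC6 (Homo sapiens) (a higher number here means a weaker inhibitor, a lower number a stronger inhibitor), compound 1 gives 500 nM. Its single companion, compound 2 `O=C(c1ccc(-c2nnc(-c3ccccc3)o2)s1)C(F)(F)F`, gives in this assay a value of 330 nM. These two numbers sit within the usual scatter of each other, so neither compound stands apart from the other on this evidence; compound 1 simply occupies one of the two places on a very short list.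

Compound 3 `O=C(c1ccc(-c2nc(-c3ccc(F)cc3F)no2)s1)C(F)(F)F` differs from compound 1 at one spot only: 2,4-difluorophenyl in place of pyridin-2-yl on an aromatic carbon. Among the compounds with values here, no measured pair in the set shows what such an exchange does, so the direction of the step is open. Since the two measured compounds differ in their aryl groups and still land within the scatter of each other, no large step is expected. The expected step of a 1.3-fold lower number from compound 1 to compound 3 (0.10 log units; within the scatter) is therefore small, either way, or none beyond the scatter. For compound 3 the estimated value in this assay is 400 nM, with a plausible range from 150 nM to 1200 nM.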

Compound 3, half-maximal inhibitory concentration: 580 nM
Estimate against measurement, compound 3: 1.5-fold (0.16 log units) below; the range from low to high includes it.
By their numbers in this assay, from the lowest: compounds 2, 1 and 3 (each within the scatter of the next).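

In this assay, putting 2,4-difluorophenyl in place of pyridin-2-yl, on the aromatic carbon between two ring nitrogen atoms, gives a 1.2-fold higher number from compound 1 to compound 3 (0.06 log units; within the scatter). Within the data shown here, compounds 1 and 2 differ in more than one place, so this is the only pair here that isolates the group at this position. It shows that a six-membered aromatic ring of carbon only, with two fluorine atoms and no hydrogen-bond acceptor, cannot be told apart in this assay from the pyridin-2-yl ring, with its ring nitrogen and one hydrogen-bond acceptor. Nothing in the data available here explains why these two groups read alike.

On these data alone, whether a group of a different kind on this carbon, such as a piperidine amine, a carboxylic acid or a longer alkyl chain, would move the number beyond the scatter remains open. Also open, as far as these compounds go, is whether the same exchange of pyridin-2-yl for 2,4-difluorophenyl would read the same way on the core of compound 2, and whether either fluorine of the 2,4-difluorophenyl group matters on its own.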